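The source may hold more compounds than are shown below. What is called first, only, known or untested is meant among the compounds shown, and "the series" means these compounds.

In a functional assay on T98G cells (Homo sapiens) for cytotoxicity, read by MTT assay, with a stated time of 48 h (on this read-out higher numbers stand for weaker inhibition and lower numbers for stronger inhibition), three compounds have so far been measured. Compound 1 `C/C(=N/NC(=S)Nc1ccccc1)c1ccccn1` gives 6.81 nM here, compound 2 `C/C(=N/NC(=S)Nc1ccc(F)cc1)c1ccccn1` gives 17 nM in the same test, and compound 3 `CC(=NNC(=S)Nc1ccc(I)cc1)c1ccccn1` gives 64 nM as the highest of the three numbers, beyond the scatter from both others. Compound 4 `C/C(=N/NC(=S)Nc1ccc(I)cc1)c1ccccn1` is still unmeasured. Its relation to compound 3 is simple: the two compounds have the same atoms and bonds; at least one stereo element is drawn with a configuration in one of them and without one in the other: 1 of 1 stereo elements differ; a double bond is drawn without a configuration in compound 3 and Z in compound 4, meaning that a double bond is drawn without a configuration in compound 3 and Z in compound 4. Within the data shown here, the only measured step is a 2.5-fold higher number from compound 1 to compound 2 (0.40 log units; beyond the scatter), a modest one for fluoro in place of hydrogen on an aromatic carbon. Among the measured compounds shown here, that step changes atoms and not a drawn configuration, so it bears on this pair only weakly, and no measured pair isolates such a change. With the same atoms and bonds on both sides, no shift beyond the scatter is expected. The estimated step is a 1.1-fold lower number from compound 3 to compound 4 (0.03 log units; within the scatter) in this assay for this pair. For compound 4 the expected value is 60 nM, with an estimated range from 25 nM to 130 nM in this test.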

Compound 4, half-maximal inhibitory concentration: 64 nM
Compound 4: the middle estimate sits 1.1-fold (0.03 log units) below what was measured, within the range that was stated.
By their numbers in this assay, from the lowest: compound 1; then compound 2; then compounds 3 and 4 (each within the scatter of the next).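

In this assay there is no change at the digits printed from compound 3 to compound 4 (within the scatter), so defining the double bond as Z leaves the number unmoved, and the pair differs in one respect only: the fact that one of compounds 3 and 4 is drawn with a defined configuration and the other without, at the place where they differ. The iodo compound can therefore be compared with the hydrogen and fluoro compounds with the double bond drawn alike on both sides. Iodo in place of fluoro gives a 3.8-fold higher number from compound 2 to compound 4 (0.58 log units; beyond the scatter), and iodo in place of hydrogen gives a 9.4-fold higher number from compound 1 to compound 4 (0.97 log units; beyond the scatter), so among these three compounds the number rises from hydrogen through fluoro to iodo.

The compounds shown leave open whether chloro or bromo at that aromatic carbon would fit this order. They also leave open how a methoxy group or an amine there would read in this assay.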